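The compounds below may be only part of what the source reports. "The series", "measured", "known", "first", "only" and "open" are said of these compounds alone.

Measured so far in an ADME assay on BJ cells (Homo sapiens), read by MTT assay, with a stated time of 72 h; on this read-out lower numbers stand for stronger inhibition and higher numbers for weaker inhibition:
- compound 1 `CSc1ncnc2c1c(-c1ccsc1)cn2[C@@H]1O[C@H](CO)[C@@H](O)[C@H]1O` gives 95800 nM
- compound 2 `CNc1ncnc2c1c(-c1ccoc1)cn2[C@@H]1O[C@H](CO)[C@@H](O)[C@H]1O` gives 96300 nM

Compound 2 stands level with compound 1, as the two values lie within the scatter of each other. Compound 3 `CNc1ncnc2c1c(-c1ccsc1)cn2[C@@H]1O[C@H](CO)[C@@H](O)[C@H]1O` has thiophen-3-yl in place of furan-3-yl on an aromatic carbon and is otherwise the same as compound 2. Compound 1 also carries thiophen-3-yl and gives 95800 nM in this assay, which suggests little change. The expected result is a 1.1-fold lower number from compound 2 to compound 3 (0.05 log units; within the scatter) and so nothing beyond the scatter. Compound 3 is estimated at 85000 nM (range 40000 nM to 130000 nM).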

Compound 3, half-maximal inhibitory concentration: > 100000 nM
Compound 3: no number, only a limit; the forecaster's own chance of this, stated with the estimate: 35%; middle value at least 1.1-fold (0.07 log units) away from the limit.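

In this assay compound 3 gives a limit and not a number: the limit of > 100000 nM in this assay, at which 1 of the 3 values shown sits. Placing thiophen-3-yl in place of furan-3-yl on this aromatic carbon gives an at least 1.0-fold higher number from compound 2 to compound 3 (0.01 log units; that floor lies within the scatter), and placing methylamino in place of methylsulfanyl gives an at least 1.0-fold higher number from compound 1 to compound 3 (0.01 log units; that floor lies within the scatter). As far as these compounds go, neither change brings a lower number, so neither shows stronger inhibition of these cells, but the full size of both steps stays unknown.

From the compounds shown here alone, whether a phenyl ring in place of thiophen-3-yl, or a longer amine chain in place of methylamino, would give a lower number stays open.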